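The source may report more compounds than this note shows. Statements on the series, on what has been measured and on what is new or still open speak of the compounds shown alone.

Measured so far:
- compound 1 `CCOC(=O)c1cnn(C)c1NC(=O)NCc1ccccc1`: 1.3 nM
- compound 2 `CCOC(=O)c1cnn(CC(O)CC)c1NC(=O)NC(C)C`: 0.0042 nM

Both values come from a functional assay on cells (Neutrophil, Homo sapiens) for inhibition, with a stated time of 10 min; a lower number here means a stronger inhibitor, a higher number a weaker inhibitor. Compound 2 has the lower number of the two, so it is the stronger inhibitor, and its gap to compound 1 lies well beyond the usual scatter.

The next compound is compound 3 `CCOC(=O)c1cnn(CC(O)CC)c1NC(=O)NCc1ccccc1`. It keeps compound 2 intact except on an amide-type nitrogen, where benzyl stands in place of isopropyl: benzyl in place of isopropyl on an amide-type nitrogen.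

Among the measured compounds shown here, no two measured compounds differ in just one place, so no measured step shows what this swap does. Compound 1 also carries benzyl and gives 1.3 nM, but it differs from compound 2 in a second place as well, so it offers only a loose hint. On that hint, a rise in the number in this assay is expected, meaning a weaker inhibitor, beyond the scatter but smaller than the whole gap between the two measured compounds.

The expected change is a 12-fold higher number from compound 2 to compound 3 (1.08 log units; beyond the scatter). For compound 3 the estimated value is 0.05 nM, with an expected range from 0.004 nM to 0.8 nM.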

Compound 3, half-maximal inhibitory concentration: 0.0074 nM
Estimate against measurement, compound 3: 6.8-fold (0.83 log units) above; the measured number falls inside the stated range.
By their numbers in this assay, from the lowest: compounds 2 and 3 (each within the scatter of the next); then compound 1.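

In this assay benzyl in place of isopropyl on an amide-type nitrogen gives a 1.8-fold higher number from compound 2 to compound 3 (0.25 log units; within the scatter) and so leaves the two groups indistinguishable at this position, although benzyl brings a six-membered aromatic ring and more heavy atoms. The large gap between compound 1 and compound 2 therefore does not trace to this nitrogen: with benzyl held constant, 1-hydroxypropyl in place of hydrogen on a saturated chain carbon bound to an aromatic nitrogen gives a 180-fold lower number from compound 1 to compound 3 (2.24 log units; beyond the scatter) and accounts for the difference between these two benzyl compounds. No measurement at hand explains why either change has the size it does.

The compounds shown leave open whether this indifference holds beyond isopropyl and benzyl, for instance with a cyclohexyl group or a chain ending in an amine on the amide-type nitrogen. They also leave open which part of the 1-hydroxypropyl group counts, the hydroxyl or the carbon chain, a question that a plain butyl chain or a carboxylic acid at the same place would help to answer.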